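A few compounds are considered here, and "the series" means these few. Any claim that something is new, unique, unknown or untested is made for them only; others in the source may bear on it.

Among the measured compounds shown here, the three compounds measured so far share one core. Compound 1 `O=C(Nc1cc(C(F)(F)F)cc(C(F)(F)F)c1)c1cc(Cl)c(-c2ccccc2)cc1O` gives 540 nM in a functional assay on Jurkat cells (Homo sapiens) for cytotoxicity, read by luminescence and CellTiter-Glo, with a stated time of 3 days; on this read-out higher numbers stand for weaker inhibition and lower numbers for stronger inhibition. Compound 2 `O=C(Nc1ccc(OC(F)(F)F)c(Cl)c1)c1ccc(C(F)(F)F)cc1O` gives 790 nM in this assay, and compound 3 `O=C(Nc1ccc(Br)c(Cl)c1)c1cc(F)ccc1O` gives 860 nM. Compound 1 has the lowest of the three numbers, yet both compound 2 and compound 3 sit within the scatter of it, so none of the three can be called stronger or weaker than another.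

Compound 4 `O=C(Nc1cc(C(F)(F)F)cc(C(F)(F)F)c1)c1cc(Br)c(-c2ccccc2)cc1O` differs from compound 1 in one place: bromo in place of chloro on an aromatic carbon. For the measured compounds named here, no measured pair shows this same exchange, so the step has to be judged from the change alone. One halogen for another at the same aromatic carbon is a small change, and the step in this assay is expected to stay within the scatter, with no clear direction. The estimate for compound 4 is 480 nM, within a range from 220 nM to 1100 nM, which amounts to an expected step of a 1.1-fold lower number from compound 1 to compound 4 (0.05 log units; within the scatter).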

Compound 4, half-maximal inhibitory concentration: 680 nM
For compound 4 the middle estimate is 1.4-fold (0.15 log units) below the measured one; the range from low to high includes it.
By their numbers in this assay, from the lowest: compounds 1, 4, 2 and 3 (each within the scatter of the next).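

In this assay, the first exchange read at this aromatic carbon, para to a hydroxy group, gives a 1.3-fold higher number from compound 1 to compound 4 (0.10 log units; within the scatter) and so lies within the scatter. Chloro and bromo therefore cannot be told apart at this position on the core of compound 1. No measurement is available that bears on this step.

The compounds shown leave open how a group other than a halogen, such as an amine, a methoxy group or a carboxylic acid, would behave at this carbon. From the compounds shown here alone, what a hydrogen in place of the neighbouring phenyl group would do also remains open.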